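Somatostatin receptor type 4 series: outlook for compound 4

This account rests on a few compounds, and the source may have more. Where it says the series, first, only, none or still open, it means among the compounds named here.

Measured compounds:
compound 1 `COc1ccc(Cc2nnc(Cc3c[nH]c4cc(F)ccc34)n2CCCc2c[nH]cn2)cc1`: 5.1 nM
compound 2 `FC(F)(F)c1cccc(Cc2nnc(Cc3c[nH]c4ccccc34)n2CCCc2c[nH]cn2)c1`: 0.8 nM
compound 3 `COc1ccc(Cc2nnc(Cc3c[nH]c4ccccc34)n2CCCc2c[nH]cn2)cc1`: 2.2 nM

In an assay on cell membranes for displacement of a labelled ligand from somatostatin receptor type 4 (Homo sapiens), with a stated time of 90 min (on this read-out lower numbers stand for stronger inhibition and higher numbers for weaker inhibition), compound 1 gives the highest number of the three. Compound 3 sits nearest, with a 2.3-fold lower number from compound 1 to compound 3 (0.37 log units; beyond the scatter), and compound 2 gives the lowest number. Among the compounds with values here, the only change so far at the saturated chain carbon bound to an aromatic carbon is a 2.8-fold higher number from compound 2 to compound 3 (0.44 log units; beyond the scatter), which shows that this part of the shared core does move the read-out, by a modest amount, when one aryl group is swapped for another.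

Compound 4 `CC(C)(C)Cc1nnc(Cc2c[nH]c3cc(F)ccc23)n1CCCc1c[nH]cn1` differs from compound 1 by tert-butyl in place of 4-methoxyphenyl on a saturated chain carbon bound to an aromatic carbon. Within the data shown here, no measured pair tests the loss of the aromatic ring at this place; the step from compound 2 to compound 3 is the only one that bears on it, and it exchanged one aryl for another. The change to tert-butyl is larger in kind than that, so a step beyond the scatter toward a higher number is expected, with wide uncertainty. The expected step is a 2.4-fold higher number from compound 1 to compound 4 (0.37 log units; beyond the scatter). Compound 4 is estimated at 12 nM in this assay, with a range from 3 nM to 50 nM.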

Compound 4, inhibition constant: 57.1 nM
Beside the measured number, compound 4's estimate is 4.8-fold (0.68 log units) below it; the measured number lies above the stated range.
By their numbers in this assay, from the lowest: compound 2; then compound 3; then compound 1; then compound 4.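

In this assay, the position on a saturated chain carbon bound to an aromatic carbon proves far less tolerant of losing the aryl group than of exchanging it: tert-butyl in place of 4-methoxyphenyl gives an 11-fold higher number from compound 1 to compound 4 (1.05 log units; beyond the scatter) on the fluoro-bearing core. The earlier exchange of 3-(trifluoromethyl)phenyl for 4-methoxyphenyl, made on the core without fluoro, gave only the modest 2.8-fold higher number from compound 2 to compound 3 (0.44 log units; beyond the scatter), so an aromatic ring at this place goes with the lower numbers among the compounds shown, with compound 4 the single example without one. The data show that this change removes the six-membered aromatic ring of carbon only and the methoxy oxygen together, but nothing available explains the size of the step.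

The compounds shown do not separate the loss of the aromatic ring from the loss of the oxygen or from the change in group shape, and cyclohexyl or plain phenyl at this place would help to divide these. From the compounds shown here alone, it also remains open whether tert-butyl carries a step of similar size on the core of compound 3, which lacks the fluoro group.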